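Replacing Cyano with 2-Methylphenyl on an Aromatic Carbon

This account rests on a few compounds, and the source may have more. Where it says the series, first, only, none or still open, it means among the compounds named here.

Of the compounds shown here, two have so far been measured in an assay on cells for agonist activity at probable G-protein coupled receptor 34 (Mus musculus), with a stated time of 1 h; on this read-out lower numbers stand for smaller maximal responses and higher numbers for larger maximal responses. Compound 1 `N[C@@H](COP(=O)(O)OCCCOC(=O)CCc1ccccc1OCc1cccc(Oc2ccc(I)cc2)c1)C(=O)O` gives 19.1% in that assay, and compound 2 `N#Cc1ccc(Oc2cccc(COc3ccccc3CCC(=O)OCCCOP(=O)(O)OC[C@H](N)C(=O)O)c2)cc1` gives 18.3%. For the measured compounds named here, the single recorded step between them, a number 0.8 percentage points lower from compound 1 to compound 2 (within the scatter), is a small one. Compound 2 thus sits at the lower end of the two numbers shown, but its nearest neighbour, compound 1, lies within the scatter of it, so no order between the two can be read from these values.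

Compound 3 `Cc1ccccc1-c1ccc(Oc2cccc(COc3ccccc3CCC(=O)OCCCOP(=O)(O)OC[C@H](N)C(=O)O)c2)cc1` differs from compound 2 in one place: 2-methylphenyl in place of cyano on an aromatic carbon. Going by the values given here, no measured step bears directly on this exchange; the only recorded one, a number 0.8 percentage points lower from compound 1 to compound 2 (within the scatter), concerns a different substituent at that aromatic carbon and stayed within the scatter. Both measured responses are low and close together, which gives no basis for expecting compound 3 to move far in this assay. The step expected is a number 1.7 percentage points higher from compound 2 to compound 3 (within the scatter), not beyond the scatter. Compound 3 is therefore estimated at 20%, with a range from 8% to 40%.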

Compound 3, largest response reached (Emax), in percent of the reference or control that the assay uses: 13.4%
Compound 3: the middle estimate sits 6.6 percentage points above what was measured; low and high end bracket the measured number.
By their numbers in this assay, from the lowest: compounds 3, 2 and 1 (each within the scatter of the next).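

For the compounds shown here, the exchange at this aromatic carbon, para to a large group, is the first to bring in a whole six-membered aromatic ring: 2-methylphenyl with its 7 heavy atoms replaces cyano with 2 heavy atoms. Even so, this assay records only a number 4.9 percentage points lower from compound 2 to compound 3 (within the scatter), and the exchange of iodo for 2-methylphenyl gives a number 5.7 percentage points lower from compound 1 to compound 3 (within the scatter), so the three substituents are not separated on this read-out and a much larger group at this position leaves the maximal response within the scatter of the smaller ones. No measurement is at hand that would account for this result or say how these substituents act at the receptor.

From the compounds shown here alone, whether an amine or a carboxylic acid on this aromatic carbon would give a response that stands apart from these three values remains open. So does whether any group at this position can lift the maximal response clear of the low range seen here, or whether that response depends on other parts of the shared core.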